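A few compounds are considered here, and "the series" means these few. Any claim that something is new, unique, unknown or untested is made for them only; others in the source may bear on it.

Three compounds of the series carry numbers in a functional assay on A549 cells (Homo sapiens) for inhibition, read by sulforhodamine B assay, with a stated time of 48 h; a lower number here means a stronger inhibitor, a higher number a weaker inhibitor. Compound 1 `COc1ccc(C(c2ccccc2O)c2cccc3ccccc23)c(OC)c1OC` gives 13600 nM. Compound 2 `COc1cc(COC(c2ccc(OC)c(OC)c2OC)c2cccc3ccccc23)cc(OC)c1` gives 17500 nM. Compound 3 `C=CCOC(c1ccc(OC)c(OC)c1OC)c1cccc2ccccc12` gives 9710 nM, the lowest of the three numbers, though neither neighbour is separated from it by more than the scatter: the step of a 1.4-fold lower number from compound 1 to compound 3 (0.15 log units; within the scatter) and the step of a 1.8-fold lower number from compound 2 to compound 3 (0.26 log units; within the scatter) are both small.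

Compound 4 `COC(=O)c1ccc(COC(c2ccc(OC)c(OC)c2OC)c2cccc3ccccc23)cc1` is not yet measured. Its difference from compound 3 is 4-(methoxycarbonyl)phenyl in place of vinyl on a saturated chain carbon bound to an oxygen on a saturated carbon. For the measured compounds named here, the one measured step at this place, a 1.8-fold lower number from compound 2 to compound 3 (0.26 log units; within the scatter), traded 3,5-dimethoxyphenyl for vinyl and stayed within the scatter; the step of a 1.4-fold lower number from compound 1 to compound 3 (0.15 log units; within the scatter) concerns another place and bears little on the question. Compound 4 puts an aryl group back at the same place, so the step expected in this assay, a 1.5-fold higher number from compound 3 to compound 4 (0.19 log units; within the scatter), is nothing beyond the scatter, at most a slightly higher number. For compound 4 the estimated value is 15000 nM, with an expected range from 7000 nM to 35000 nM.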

Compound 4, half-maximal inhibitory concentration: 12000 nM
The estimate for compound 4 lay 1.3-fold (0.10 log units) above the measured number; low and high end bracket the measured number.
By their numbers in this assay, from the lowest: compounds 3, 4, 1 and 2 (each within the scatter of the next).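

Working notes on the place on a saturated chain carbon bound to an oxygen on a saturated carbon: in this assay, the step of a 1.2-fold higher number from compound 3 to compound 4 (0.09 log units; within the scatter) shows that 4-(methoxycarbonyl)phenyl, with its six-membered aromatic ring and two hydrogen-bond acceptors, gives a number that does not separate from that of the vinyl compound. The step of a 1.5-fold lower number from compound 2 to compound 4 (0.16 log units; within the scatter) adds a comparison between two aryl groups at this place, and it too stays within the scatter, so these three compounds show no dependence on the group here. No supporting data bear on this result.

Going by these compounds, whether a carboxylic acid in place of the methyl ester, an amine on the benzyl ring or a longer chain at this place would move the number beyond the scatter remains open. The compounds shown also leave open whether any group at this place can do so.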